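Swapping methoxy for chloro on the pendant aryl ring

The source may report more compounds than this note shows. Statements on the series, on what has been measured and on what is new or still open speak of the compounds shown alone.

Of the compounds shown here, three sharing one core have been tested in a functional assay on cells (Cancer cell lines, Homo sapiens) for cytotoxicity, read by sulforhodamine B assay, with a stated time of 48 h; a lower number here means a stronger inhibitor of growth, a higher number a weaker inhibitor of growth. Compound 1 `COc1ccc(C2CC(c3ccccc3)=NN2C2=NC(=O)/C(=C3\C(=O)Nc4ccc(Br)cc43)S2)cc1` gives 200 nM. Compound 2 `COc1ccc(C2=NN(C3=NC(=O)/C(=C4\C(=O)Nc5ccc(Br)cc54)S3)C(c3ccc(OC)cc3)C2)cc1` gives 210 nM, the second highest of the three numbers, and compound 3 `COc1ccc(C2=NN(C3=NC(=O)/C(=C4\C(=O)Nc5ccc(Cl)cc54)S3)C(c3ccc(OC)cc3)C2)cc1` gives 220 nM; all three lie within the usual scatter of one another. The step of a 1.1-fold higher number from compound 1 to compound 2 (0.02 log units; within the scatter) changed the same ring that now changes again, and the step of a 1.0-fold higher number from compound 2 to compound 3 (0.02 log units; within the scatter) touched a different ring; neither moved the number beyond the scatter. Compound 4 `COc1ccc(C2=NN(C3=NC(=O)/C(=C4\C(=O)Nc5ccc(Br)cc54)S3)C(c3ccc(Cl)cc3)C2)cc1` differs from compound 2 by chloro in place of methoxy on an aromatic carbon. With both nearby steps flat, no shift beyond the scatter is expected here: compound 4 is estimated at 210 nM, with a range of 110 nM to 400 nM, a step of no change at the digits printed from compound 2 to compound 4 (within the scatter).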

Compound 4, concentration for 50% growth inhibition: 140 nM
Compound 4: the middle estimate sits 1.5-fold (0.18 log units) above what was measured, within the range that was stated.
By their numbers in this assay, from the lowest: compounds 4, 1, 2 and 3 (each within the scatter of the next).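

In this assay, going from 4-methoxyphenyl to 4-chlorophenyl gives a 1.5-fold lower number from compound 2 to compound 4 (0.18 log units; within the scatter). Compounds 1, 2 and 3 all carry methoxy on this ring, whereas compound 4 shows that a single chlorine atom, with no hydrogen-bond acceptor, can stand at this place without a shift beyond the scatter, so the methoxy is not needed here. No available evidence bears on this result. Still open, as far as these compounds go, is whether an amine, a carboxylic acid or a longer chain such as butoxy at this place would keep the number in the same range.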